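Swapping methoxy for methyl at the assay limit

The source may hold more compounds than are shown below. What is called first, only, known or untested is meant among the compounds shown, and "the series" means these compounds.

Compound 1 `C#CCn1c(=O)c(C=O)cc2ccccc21` gives > 100000 nM
Compound 2 `C#CCn1c(=O)c(C=O)cc2cc(F)ccc21` gives > 100000 nM
Compound 3 `C#CCn1c(=O)c(C=O)cc2cc(OC)ccc21` gives > 100000 nM

All three values come from a functional assay on A549 cells (Homo sapiens) for cytotoxicity, read by MTT assay, with a stated time of 24 h (a lower number here means a stronger inhibitor, a higher number a weaker inhibitor), and each is a limit, not a number. Compound 3 stands at the limit of > 100000 nM in this assay, at which 3 of the 3 values shown sit. Compound 4 `C#CCn1c(=O)c(C=O)cc2cc(C)ccc21` has methyl in place of methoxy on an aromatic carbon. The measured changes that bear on this are a step that the two limits leave unreadable from compound 1 to compound 3 and a step that the two limits leave unreadable from compound 2 to compound 3, so neither offers a size to carry over. No step beyond the scatter, in either direction, is therefore expected in this assay. The expected outcome is a number no higher from compound 3 to compound 4 (the limit leaves the size open). Compound 4 is estimated at 100000 nM, with an expected range from 50000 nM to 200000 nM.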

Compound 4, half-maximal inhibitory concentration: > 100000 nM
Compound 4 ended at the assay's limit; the forecaster's own chance of this, stated with the estimate: 90%; the middle value sits exactly at the limit.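

Compound 4 also gives only a limit, as do compound 1, compound 2 and compound 3, so no step among them can be read: the limit of > 100000 nM in this assay, at which 4 of the 4 values shown sit.

The compounds shown leave open how far apart these four truly lie, and whether any group at this place would give a readable value.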